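A Methylsulfonyl Aryl Swap on Compound 1

The source may hold more compounds than are shown below. What is called first, only, known or untested is meant among the compounds shown, and "the series" means these compounds.

In an ADME assay on microsomes from liver (Rattus norvegicus) for metabolic stability, read by LC-MS, tested at 1 mM (on this read-out higher numbers stand for a longer-lived compound and lower numbers for a shorter-lived compound), compound 1 `N#Cc1ccc(F)cc1Cn1c(N2CCC[C@@H](N)C2)nc2c(-c3ccc(F)cc3)c[nH]c2c1=O` gives 1.21 h and stands within the scatter of both other measured compounds. Compound 2 `N#Cc1ccc(F)cc1Cn1c(N2CCC[C@@H](N)C2)nc2c(F)c[nH]c2c1=O` gives 0.838 h, and compound 3 `CS(=O)(=O)c1ccc(-c2c[nH]c3c(=O)n(Cc4cc(F)ccc4C#N)c(N4CCC[C@@H](N)C4)nc23)c(F)c1` gives 1.59 h. The unmeasured compound 4 `CS(=O)(=O)c1ccc(-c2c[nH]c3c(=O)n(Cc4cc(F)ccc4C#N)c(N4CCC[C@@H](N)C4)nc23)cc1F` differs from compound 1 by 3-fluoro-4-(methylsulfonyl)phenyl in place of 4-fluorophenyl on an aromatic carbon, with 3-fluoro-4-(methylsulfonyl)phenyl in place of 4-fluorophenyl on an aromatic carbon.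

The closest evidence is the swap to 2-fluoro-4-(methylsulfonyl)phenyl, which gave a 1.3-fold higher number from compound 1 to compound 3 (0.12 log units; within the scatter). Fluoro in place of 4-fluorophenyl gave a 1.4-fold lower number from compound 1 to compound 2 (0.16 log units; within the scatter), and 2-fluoro-4-(methylsulfonyl)phenyl in place of fluoro gave a 1.9-fold higher number from compound 2 to compound 3 (0.28 log units; within the scatter). For the measured compounds named here, none of these three steps leaves the scatter, but no measured compound carries the 3-fluoro-4-(methylsulfonyl)phenyl group itself, so the evidence is indirect. No change beyond the scatter is therefore expected in this assay. The expected step is a 1.2-fold higher number from compound 1 to compound 4 (0.09 log units; within the scatter). The estimate for compound 4 is 1.5 h, with an expected range from 0.8 h to 2.8 h.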

Compound 4, half-life: 2.78 h
Compound 4: middle estimate off by 1.9-fold (0.27 log units), on the low side, and the stated range covers the measured number.
By their numbers in this assay, from the lowest: compounds 2, 1, 3 and 4 (each within the scatter of the next, the first and the last beyond it).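

In this assay, the 3-fluoro-4-(methylsulfonyl)phenyl group is the only group shown at this position whose steps leave the scatter, with a 2.3-fold higher number from compound 1 to compound 4 (0.36 log units; beyond the scatter) and a 3.3-fold higher number from compound 2 to compound 4 (0.52 log units; beyond the scatter). It still cannot be separated from its 2-fluoro-4-(methylsulfonyl)phenyl counterpart, with a 1.7-fold higher number from compound 3 to compound 4 (0.24 log units; within the scatter), so the data do not show that the place of the ring fluorine matters, even though only compound 4 stands clear of compound 1. No measurement shown accounts for this difference.

The compounds shown leave open whether a phenyl ring carrying methylsulfonyl and no fluorine would match compound 4 at this position. They also leave open whether a sulfonamide or a carboxylic acid in place of the methylsulfonyl group would do the same.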